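The source may report more compounds than this note shows. Statements on the series, on what has been measured and on what is new or still open speak of the compounds shown alone.

Three measured compounds share an anilinoquinazoline-like arrangement in which a sulfonamide-bearing aniline is attached to the shared core, and all were tested in a functional assay on A-431 cells (Homo sapiens) for antiproliferative activity, read by MTT assay, with a stated time of 72 h; a higher number here means a weaker inhibitor, a lower number a stronger inhibitor. Compound 1 `COc1cc2ncnc(Nc3cccc(Cl)c3)c2cc1OCCCCC(=O)Nc1ccc(S(N)(=O)=O)cc1` gives 30400 nM. Compound 2 `COc1cc2ncnc(Nc3cccc(F)c3)c2cc1OCCCCC(=O)Nc1ccc(S(N)(=O)=O)cc1` gives 29900 nM. Compound 3 `NS(=O)(=O)c1ccc(NC(=S)Nc2ccc3ncnc(Nc4cccc(F)c4)c3c2)cc1` gives 30100 nM. The three numbers lie on top of one another: the step of a 1.0-fold higher number from compound 2 to compound 1 (0.01 log units; within the scatter), where the change is chloro in place of fluoro on an aromatic carbon, and the values of compound 3 and compound 2 fall together within the scatter, as do those of compound 3 and compound 1. How the core of compound 3 differs from the core of compound 2 is not broken down here; the two differ in more than one place.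

Compound 4 `NS(=O)(=O)c1ccc(NC(=S)Nc2ccc3ncnc(Nc4cccc(Cl)c4)c3c2)cc1` stands to compound 3 as compound 1 stands to compound 2: the change is chloro in place of fluoro on an aromatic carbon, at the same place in the same words, so it is the same change, seen twice among these four compounds. The earlier occurrence, from compound 2 to compound 1, produced no movement beyond the scatter, and the three measured numbers are so close that nothing in them suggests the change should behave otherwise on the core of compound 3. On that basis compound 4 is expected to sit near compound 3, with an expected step of a 1.0-fold lower number from compound 3 to compound 4 (0.00 log units; within the scatter). For compound 4 the estimate in this assay is 30000 nM, with a range expected between 15000 nM and 60000 nM.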

Compound 4, half-maximal inhibitory concentration: 15000 nM
Estimate against measurement, compound 4: 2.0-fold (0.30 log units) above; low and high end bracket the measured number.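

In this assay, chloro in place of fluoro on an aromatic carbon gives a 2.0-fold lower number from compound 3 to compound 4 (0.30 log units; within the scatter), so on the core of compound 3 this pair shows no change that can be told from the scatter. The same exchange on the other core gives a result that cannot be told apart from this one: the same change on two cores in this assay, a 1.0-fold higher number (0.01 log units; within the scatter) from compound 2 to compound 1 and a 2.0-fold lower number (0.30 log units; within the scatter) from compound 3 to compound 4, 2.0-fold (0.31 log units) apart, within the scatter of two such steps. Within the data shown here, this shows that, for these two pairs, the fluoro-to-chloro exchange carries from one core to the other without a measurable difference, but it rests on only two pairs, neither of which has a step beyond the scatter, so it shows only that two small steps agree, not that a change with a clear effect on one core would carry over to the other, or that the agreement extends to further cores.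

The compounds shown leave open whether a bromo or a methyl group on the same aromatic carbon would also stay within the scatter on both cores. They also leave open how these cores would respond if a carboxylic acid replaced the sulfonamide, or if a longer chain replaced the linking chain of compound 1 and compound 2.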